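Phenyl for thiophenyl on the fused core: compound 4

The source may report more compounds than this note shows. Statements on the series, on what has been measured and on what is new or still open speak of the compounds shown alone.

The series shares the core of compound 1 `CCNC(=O)c1oc2nc(-c3ccccc3)cc(C(F)(F)F)c2c1N`, which in an ADME assay on HEK293 cells (Homo sapiens) for antiproliferative activity, read by MTT assay (a higher number here means a weaker inhibitor, a lower number a stronger inhibitor), gives 70000 nM. Compound 2 `Nc1c(C(=O)N/N=C/c2ccccc2)oc2nc(-c3ccccc3)cc(C(F)(F)F)c12` carries a larger group on the amide-type nitrogen and in this assay gives 70000 nM; the step of no change at the digits printed from compound 1 to compound 2 (within the scatter). Compound 3 `CCCNC(=O)c1oc2nc(-c3cccs3)cc(C(F)(F)F)c2c1N`, with a propyl amide and a thiophen-2-yl group, in this assay gives 64000 nM. All three numbers lie within the usual scatter of one another, so the data so far show no separation among these compounds.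

Compound 4 `CCCNC(=O)c1oc2nc(-c3ccccc3)cc(C(F)(F)F)c2c1N` differs from compound 3 in one place: phenyl in place of thiophen-2-yl on an aromatic carbon. For the measured compounds named here, no measured step in this assay addresses this exchange directly. Compound 1 and compound 3 differ in two places, one of them this same exchange, and their values in this assay sit within the scatter of each other; the step from compound 1 to compound 2, at a different site, also stayed within the scatter. The expectation is therefore that the exchange in compound 4 produces no step beyond the scatter, a 1.0-fold higher number from compound 3 to compound 4 (0.02 log units; within the scatter). Compound 4 is estimated in this assay at 67000 nM, with a range from 35000 nM to 130000 nM.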

Compound 4, half-maximal inhibitory concentration: 81000 nM
Compound 4: middle estimate off by 1.2-fold (0.08 log units), on the low side; the measured number falls inside the stated range.
By their numbers in this assay, from the lowest: compounds 3, 1, 2 and 4 (each within the scatter of the next).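

In this assay, phenyl in place of thiophen-2-yl on the aromatic carbon next to the ring nitrogen can now be read as a single change, and it gives a 1.3-fold higher number from compound 3 to compound 4 (0.10 log units; within the scatter), whereas the earlier comparison at this position also carried a change in the amide chain. The amide side can be read in the same way: methyl in place of hydrogen on the saturated chain gives a 1.2-fold higher number from compound 1 to compound 4 (0.06 log units; within the scatter), and a propyl chain in place of the larger group on the amide-type nitrogen gives a 1.2-fold higher number from compound 2 to compound 4 (0.06 log units; within the scatter), so none of these single changes separates the compounds. Nothing available explains why these values stay together or links them to any property of the groups.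

As far as these compounds go, it remains open whether a carboxylic acid or a morpholine at the end of the amide chain, or a pyridine ring in place of phenyl on the aromatic carbon, would give a step beyond the scatter in this assay. From the compounds shown here alone, the trifluoromethyl group stands unchanged in all four compounds, and the exchange for a nitrile there remains open.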